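The source may report more compounds than this note shows. Statements on the series, on what has been measured and on what is new or still open speak of the compounds shown alone.

Compound 1 `CC1=C(C(=O)Nc2ccc(F)cc2)C(c2ccc([N+](=O)[O-])cc2)N=C(SCc2ccccc2)N1`: 32.3%
Compound 2 `CC1=C(C(=O)Nc2ccc(F)cc2)C(c2ccc([N+](=O)[O-])cc2)N=C(SCc2ccccc2Cl)N1`: 17.4%
Compound 3 `CC1=C(C(=O)Nc2ccc([N+](=O)[O-])cc2)C(c2ccc(Br)cc2)N=C(SCc2ccccc2)N1`: 27.2%

In a functional assay on the whole organism (artery, strain albino) with Rattus norvegicus as the target, with a stated time of 600 min, at a dose of 10 mg/kg by the oral route (on this read-out higher numbers stand for more inhibition at the one dose given (going by the name of the read-out) and lower numbers for less inhibition), compound 1 gives 32.3%, and the change chloro in place of hydrogen on an aromatic carbon made a number 14.9 percentage points lower from compound 1 to compound 2 (beyond the scatter). Compound 3 shares the same change site but has a different core; the difference between the two cores is not broken down here, and its value in this assay sits within the scatter of compound 1.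

Compound 4 `CC1=C(C(=O)Nc2ccc([N+](=O)[O-])cc2)C(c2ccc(Br)cc2)N=C(SCc2ccccc2Cl)N1` has not yet been measured. It arises from compound 3 by chloro in place of hydrogen on an aromatic carbon, the same change at the same kind of place as from compound 1 to compound 2. Going by the values given here, compound 4 is expected to show a step of a number 14.2 percentage points lower from compound 3 to compound 4 (beyond the scatter), set beside the earlier step, because that single step a number 14.9 percentage points lower from compound 1 to compound 2 (beyond the scatter) is the only guide here. Compound 4 is therefore estimated at 13% in this assay, between 0% and 28%.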

Compound 4, a percentage reported as inhibition, in the whole organism at one dose (the size of the read-out at that dose, not a potency): 9.7%
Compound 4: the middle estimate sits 3.3 percentage points above what was measured; measured number inside the range.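

In this assay the change from benzylsulfanyl to (2-chlorobenzyl)sulfanyl gave a number 17.5 percentage points lower from compound 3 to compound 4 (beyond the scatter) on the core of compound 3. The change therefore carried across the two cores shown, and the size of the step held within the scatter: the same change on two cores in this assay, a number 14.9 percentage points lower (beyond the scatter) from compound 1 to compound 2 and a number 17.5 percentage points lower (beyond the scatter) from compound 3 to compound 4, 2.6 percentage points apart, within the scatter of two such steps. Going by these compounds alone, this rests on only two pairs at one oral dose, and it does not show that the step would hold on any further core or explain why the number falls.

The compounds shown leave open whether a methoxy group, an amine or a carboxylic acid in place of the chloro would lower the number in the same way. They also leave open what a longer chain in place of benzyl would do.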